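Nitrooxy chain change from compound 1 to compound 4

The source may hold more compounds than are shown below. What is called first, only, known or untested is meant among the compounds shown, and "the series" means these compounds.

Measured values (a functional assay on LOX IMVI cells (Homo sapiens) for cytotoxicity, read by resazurin assay, with a stated time of 72 h; on this read-out higher numbers stand for weaker inhibition and lower numbers for stronger inhibition)
compound 1 (`COc1cc(/C=C/C(=O)OCCCCCCO[N+](=O)[O-])ccc1O`) gives > 50000 nM
compound 2 (`O=C(/C=C/c1ccc(OCCCCCO[N+](=O)[O-])c(O)c1)OCCCCCO[N+](=O)[O-]`) gives 7230 nM
compound 3 (`COc1cc(/C=C/C(=O)Oc2ccc(OCc3c(-c4ccccc4)no[n+]3[O-])cc2)ccc1O`) gives > 50000 nM

Compound 1 sits at a limit of the assay (> 50000 nM) and has no number. Compound 3 is likewise a limit (> 50000 nM). The series is thus marked by the limit of > 50000 nM in this assay, at which 2 of the 3 values shown sit, and only compound 2 gives a number (7230 nM). Compound 4 (`COc1cc(/C=C/C(=O)OCCCO[N+](=O)[O-])ccc1O`) is still to be measured in this assay and carries nitrooxy in place of 3-(nitrooxy)propyl on a saturated chain carbon, three bonds along the chain from an oxygen next to a carbonyl group. Among the measured compounds shown here, no measured pair isolates this change. With compound 1 at a limit (> 50000 nM) no step beyond the usual scatter is expected. The expected step is a number no higher from compound 1 to compound 4 (the limit leaves the size open) and it carries no change in direction. For compound 4 the estimated value is 50000 nM with an expected range from 20000 nM to 100000 nM.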

Compound 4, half-maximal inhibitory concentration: 29500 nM
The estimate for compound 4 lay 1.7-fold (0.23 log units) above the measured number; low and high end bracket the measured number.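

With nitrooxy in place of 3-(nitrooxy)propyl at this saturated chain carbon, compound 4 gives an actual number in this assay: 29500 nM. Compound 1 gives only a limit, > 50000 nM. The pair reads as an at least 1.6-fold lower number from compound 1 to compound 4 (0.22 log units; that floor lies within the scatter), so the change is tolerated here, but a real gain is not established.

From the compounds shown here alone, how far a number can be reached at this position remains open, and the series is still largely bounded: the limit of > 50000 nM in this assay, at which 2 of the 4 values shown sit. Whether a still longer chain or a carboxylic acid at the chain end would shift the value also stays unresolved.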